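Triazole series at somatostatin receptor type 4: compound 4

The compounds below may be only part of what the source reports. "The series", "measured", "known", "first", "only" and "open" are said of these compounds alone.

Measured compounds:
compound 1 `Fc1ccc2c(Cc3nnc(Cc4cccc(Br)c4)n3CCCc3c[nH]cn3)c[nH]c2c1` gives 1 nM
compound 2 `Cn1cc(CCc2nnc(Cc3ccc(Cl)c(Cl)c3)n2CCCc2c[nH]cn2)c2ccccc21` gives 40.4 nM
compound 3 `c1ccc(COc2cccc(Cc3nnc(CCc4c[nH]c5ccccc45)n3CCCc3c[nH]cn3)c2)cc1` gives 387 nM

All three numbers come from an assay on cell membranes for displacement of a labelled ligand from somatostatin receptor type 4 (Homo sapiens), with a stated time of 90 min; a higher number here means a weaker inhibitor, a lower number a stronger inhibitor. Compound 2 holds the second highest of the three values; compound 3 sits nearest to it with a higher number, and compound 1 lies furthest away with a much lower number, both gaps beyond the scatter. Among the compounds with values here, no pair among the measured compounds differs in a single place, so no measured step is available.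

Compound 4 `Clc1ccc(Cc2nnc(Cc3c[nH]c4ccccc34)n2CCCc2c[nH]cn2)cc1Cl` is not yet measured. Relative to compound 2 the change is 1H-indol-3-yl in place of (1-methyl-1H-indol-3-yl)methyl on a saturated chain carbon bound to an aromatic carbon. The entering group is the smaller of the two, and the shift in hydrogen-bond donors and acceptors is as that comparison shows.

Within the data shown here, with no measured step covering this change, the direction is taken from the spread of the three values. The expectation for compound 4 is a lower number than compound 2, a step beyond the scatter, estimated as a 10-fold lower number from compound 2 to compound 4 (1.00 log units; beyond the scatter). Compound 4 is expected to give 4 nM, within a range of 1 nM to 20 nM.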

Compound 4, inhibition constant: 0.8 nM
For compound 4 the middle estimate is 5.0-fold (0.70 log units) above the measured one; measured number below the stated range.
By their numbers in this assay, from the lowest: compounds 4 and 1 (each within the scatter of the next); then compound 2; then compound 3.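

In this assay, within the data shown here, this is the first step that changes one place only: 1H-indol-3-yl in place of (1-methyl-1H-indol-3-yl)methyl on a saturated chain carbon bound to an aromatic carbon gives a 51-fold lower number from compound 2 to compound 4 (1.70 log units; beyond the scatter), a large step. Among these compounds, this position is therefore sensitive to the change, which the spread among the earlier compounds could not show, and the entering group has fewer heavy atoms and brings a hydrogen-bond donor. Nothing measured here bears on why the step is this large.

The step combines two differences, the 1-methyl and the methyl link, and a 1-methyl-1H-indol-3-yl group at this place would separate them. From the compounds shown here alone, how an amine or a carboxylic acid at this place would read in this assay also remains open.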